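From chloro to hydroxy: working notes on compound 3

A few compounds are considered here, and "the series" means these few. Any claim that something is new, unique, unknown or untested is made for them only; others in the source may bear on it.

Among the compounds with values here, in a functional assay on HepG2 cells (Homo sapiens) for cytotoxicity, read by MTT assay, with a stated time of 48 h (a higher number here means a weaker inhibitor, a lower number a stronger inhibitor), compound 1 `C=CC(C)(O)CC[C@@H]1C(=C)CC[C@H](Br)[C@@]1(C)CCC(O)C(C)(C)Cl` gives 48700 nM, the only compound here with a single plain number. Compound 2 `C=CC(C)(O)CC[C@@H]1C(=C)CC[C@H](Br)[C@@]1(C)CCC(Br)C(C)(C)O` gives > 100000 nM; 66300 nM (2 entries). One other entry of compound 2 is a limit of the assay and not a number. The numeric entry of compound 2 stays within the usual scatter of compound 1.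

Compound 3 `C=CC(C)(O)CC[C@@H]1C(=C)CC[C@H](Br)[C@@]1(C)CCC(O)C(C)(C)O` has not yet been measured. It differs from compound 1 by hydroxy in place of chloro on a saturated chain carbon bound to three saturated chain carbons, with hydroxy in place of chloro on a saturated chain carbon bound to three saturated chain carbons.

Within the data shown here, no measured step covers this change. A small step toward weaker inhibition in this assay, close to the scatter, is expected because compound 2, with hydroxy on such a carbon, reads (the several entries of compound 2 in this assay, > 100000 nM; 66300 nM (2 entries)). The estimated change is a 1.4-fold higher number from compound 1 to compound 3 (0.16 log units; within the scatter). For compound 3 the expected value is 70000 nM, with an estimated range of 35000 nM to 140000 nM.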

Compound 3, half-maximal inhibitory concentration: > 100000 nM
Compound 3: no number, only a limit; the forecaster's own chance of this, stated with the estimate: 35%; middle value at least 1.4-fold (0.15 log units) from the limit.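

In this assay compound 3 gives > 100000 nM, which is a limit of the assay and not a number. Within the data shown here, this provides the first measured step at this place: hydroxy in place of chloro on a saturated chain carbon bound to three saturated chain carbons gives an at least 2.0-fold higher number from compound 1 to compound 3 (0.31 log units; beyond the scatter), so the direction of the change is now fixed beyond the scatter, while its size remains only a lower bound. The earlier compounds offered no step of this kind, and the limit recurs in this small set: the limit of > 100000 nM in this assay, at which 1 of the 3 values shown sits.

On these data alone, the full size of the step in this assay remains open, since a limit cannot show how far the true value of compound 3 lies from it. Also open, as far as these compounds go, is how an amine or a methoxy group on this same carbon would read against chloro and hydroxy.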